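This account rests on a few compounds, and the source may have more. Where it says the series, first, only, none or still open, it means among the compounds named here.

In a functional assay on HGC-27 cells (Homo sapiens) for inhibition, read by MTT assay, with a stated time of 72 h (a higher number here means a weaker inhibitor, a lower number a stronger inhibitor), compound 1 `Cc1cc(N2CC[C@@H](C)[C@@H](N(C)c3ncnc4[nH]ccc34)C2)n2nc(SCC3CC3)nc2n1` gives 21400 nM. Compound 2 `Cc1nc2nc(SCc3ccc(Cl)cc3)nn2c(N2CC[C@@H](C)[C@@H](N(C)c3ncnc4[nH]ccc34)C2)c1C` gives only a limit, > 100000 nM. As far as these compounds go, compound 3 `Cc1cc(N2CC[C@@H](C)[C@@H](N(C)c3ncnc4[nH]ccc34)C2)n2nc(SCc3csc4ccc(Cl)cc34)nc2n1` also gives only a limit, > 100000 nM, so its true value is unknown. Compound 4 `C=CCSc1nc2nc(C)cc(N3CC[C@@H](C)[C@@H](N(C)c4ncnc5[nH]ccc45)C3)n2n1` differs from compound 3 by one change, (vinyl in place of 5-chloro-1-benzothiophen-3-yl on a saturated chain carbon bound to a sulfur), with vinyl in place of 5-chloro-1-benzothiophen-3-yl on a saturated chain carbon bound to a sulfur. For the measured compounds named here, the one measured step bearing on this is an at least 4.6-fold higher number from compound 1 to compound 3 (0.66 log units; beyond the scatter), which brought in the same large group at that place, replacing cyclopropyl. Removing that group again should reverse this step, so a move of at least similar size toward lower numbers is expected in this assay, namely an at least 4.0-fold lower number from compound 3 to compound 4 (0.60 log units; beyond the scatter). For compound 4 the estimated value is 25000 nM, with an expected range of 8000 nM to 80000 nM.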

Compound 4, half-maximal inhibitory concentration: 35200 nM
Beside the measured number, compound 4's estimate is 1.4-fold (0.15 log units) below it; measured number inside the range.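

In this assay, the loss of inhibition reverses when vinyl replaces 5-chloro-1-benzothiophen-3-yl, an at least 2.8-fold lower number from compound 3 to compound 4 (0.45 log units; beyond the scatter), so the loss follows that group and not the place itself. Vinyl and cyclopropyl cannot be told apart at this place, a 1.6-fold higher number from compound 1 to compound 4 (0.22 log units; within the scatter). The first of these steps is only a bound because the value it starts from is a limit: the limit of > 100000 nM in this assay, at which 2 of the 4 values shown sit.

As far as these compounds go, whether an amine, a carboxylic acid or a longer chain at this place would lower the number beyond that of compound 1 remains open.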